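This account rests on a few compounds, and the source may have more. Where it says the series, first, only, none or still open, it means among the compounds named here.

Among the compounds with values here, compound 1 `Cc1n[nH]c(C(=O)O)c1Cc1ccc(-c2ccc(OC(F)(F)F)cc2)cc1` gives 29% in an assay on isolated protein for inhibition of 2-Hydroxyacid oxidase 2 (Homo sapiens), tested at 10 uM (a lower number here means a weaker effect, a higher number a stronger effect of the compound at the concentration tested), the highest of the two numbers measured so far. Compound 2 `Cc1n[nH]c(C(=O)O)c1Cc1ccc(C(F)(F)F)cc1` gives 12% in this assay, a number beyond the scatter below compound 1. Compound 3 `Cc1n[nH]c(C(=O)O)c1Cc1ccc(-c2ccc(C(F)(F)F)cc2)cc1`, not yet measured, keeps the core and the outer ring of compound 1 and differs by trifluoromethyl in place of trifluoromethoxy on an aromatic carbon. Within the data shown here, with no measured pair showing this exchange, the step is expected to be small, if anything slightly downward, and likely within the scatter: a number 5 percentage points lower from compound 1 to compound 3 (within the scatter). Compound 3 is therefore estimated at 24%, with a range of 8% to 40%.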

Compound 3, a percentage reported as inhibition, at one concentration (the size of the read-out at that concentration, not a potency): 14%
Compound 3: middle estimate off by 10 percentage points, on the high side, and the stated range covers the measured number.
By their numbers in this assay, from the lowest: compounds 2 and 3 (each within the scatter of the next); then compound 1.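

On the outer ring, at the carbon para to a large group, trifluoromethyl in place of trifluoromethoxy gives a number 15 percentage points lower from compound 1 to compound 3 (beyond the scatter) in this assay. This position therefore responds to an exchange between two closely related groups, and trifluoromethoxy holds the higher number of the pair. No data at hand give a reason for this step.

Still open, on these data alone, is how methoxy, chlorine or an amine would read at this position. As far as these compounds go, it is also open whether an amide in place of the carboxylic acid on the shared core would keep the effect of compound 1.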